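Trimming isopropoxy to ethoxy in compound 4

A few compounds are considered here, and "the series" means these few. Any claim that something is new, unique, unknown or untested is made for them only; others in the source may bear on it.

In an ADME assay on the whole organism (Rattus norvegicus) for pharmacokinetics, read by LC-MS (on this read-out higher numbers stand for higher oral bioavailability and lower numbers for lower oral bioavailability), compound 1 (`COc1ccc2c(c1C(=O)O)OB(O)[C@@H](Sc1nncs1)C2`) gives 3%, compound 2 (`COc1ccc2c(c1C(=O)OCOC(=O)C(C)C)OB(O)[C@@H](Sc1nncs1)C2`) gives 100% and compound 3 (`COc1ccc2c(c1C(=O)OCOC(=O)OC(C)C)OB(O)[C@@H](Sc1nncs1)C2`) gives 94%. Compound 3 thus stands with compound 2 at the high end of the three numbers, far from compound 1. Installing ((isopropoxycarbonyl)oxy)methyl produced a number 91 percentage points higher from compound 1 to compound 3 (beyond the scatter), and ((isopropylcarbonyl)oxy)methyl produced a number 97 percentage points higher from compound 1 to compound 2 (beyond the scatter). Compound 4 (`CCOC(=O)OCOC(=O)c1c(OC)ccc2c1OB(O)[C@@H](Sc1nncs1)C2`) keeps that arrangement but has isopropoxy changed to ethoxy: hydrogen in place of methyl on a saturated chain carbon bound to an oxygen next to a carbonyl group and a saturated chain carbon. Among the compounds with values here, the nearest precedent, a change in the same outer group, is a number 6 percentage points lower from compound 2 to compound 3 (within the scatter), so no shift beyond the scatter is expected. The expected step is a number 7 percentage points lower from compound 3 to compound 4 (within the scatter). Compound 4 is estimated at 87%, with an expected range of 65% to 100%.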

Compound 4, oral bioavailability: 64%
Compound 4: middle estimate off by 23 percentage points, on the high side; measured number below the stated range.
By their numbers in this assay, from the lowest: compound 1; then compound 4; then compounds 3 and 2 (each within the scatter of the next).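

In this assay this outer part of the ester turns out to be sensitive to one methyl: isopropoxy to ethoxy gives a number 30 percentage points lower from compound 3 to compound 4 (beyond the scatter), whereas isopropyl to isopropoxy stayed within the scatter. Ethoxy in place of isopropyl gives a number 36 percentage points lower from compound 2 to compound 4 (beyond the scatter), while ((ethoxycarbonyl)oxy)methyl still leaves a number 61 percentage points higher from compound 1 to compound 4 (beyond the scatter), so much of the gain survives. Nothing at hand gives a reason for this drop. On these data alone, whether methoxy would fall further, or whether a longer chain such as butoxy or a ring such as cyclohexyloxy would restore the number, stays open.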